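The source may report more compounds than this note shows. Statements on the series, on what has been measured and on what is new or still open speak of the compounds shown alone.

In a functional assay on A549 cells (Homo sapiens) for cytotoxicity, read by MTT assay, with a stated time of 72 h (a higher number here means a weaker inhibitor, a lower number a stronger inhibitor), compound 1, `Cc1ccc2[nH]c(-n3cccn3)c(C3=C(Br)C(=O)NC3=O)c2c1`, gives 29000 nM. Compound 3, `COc1ccc2[nH]c3c(c4c(c5ccnn53)C(=O)NC4=O)c2c1`, gives 8000 nM, so compound 1 carries the higher of the two numbers, and the gap between them lies beyond the usual scatter. Compound 2, `Cc1ccc2[nH]c3c4cn[nH]c4c4c(c3c2c1)C(=O)NC4=O`, stands at > 100000 nM, which is a limit of the measurement and not a number.

The next compound to be tested is compound 4, `O=C1NC(=O)C(c2c(-n3cccn3)[nH]c3ccccc23)=C1Br`. It differs from compound 1 in one place, with hydrogen in place of methyl on an aromatic carbon of a six-membered aromatic ring of carbon only: hydrogen in place of methyl on an aromatic carbon. Among the compounds with values here, no two measured compounds differ in one place alone, so the data give no direct size for this change. Compounds 2 and 3 also differ from compound 1 in more than this one group and cannot stand in for it.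

In this assay, the expectation is therefore no step beyond the scatter, with neither direction favoured, and the starting point is compound 1 at 29000 nM. The estimated change is a 1.0-fold higher number from compound 1 to compound 4 (0.01 log units; within the scatter). For compound 4 the expected value is 30000 nM. The estimated range for compound 4 runs from 12000 nM to 75000 nM.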

Compound 4, half-maximal inhibitory concentration: 25000 nM
Beside the measured number, compound 4's estimate is 1.2-fold (0.08 log units) above it; the range from low to high includes it.
By their numbers in this assay, from the lowest: compound 3; then compounds 4 and 1 (each within the scatter of the next). At a limit, above all of these: compound 2.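

In this assay, within the data shown here, the pair gives the first step between two compounds that differ in one place: a 1.2-fold lower number from compound 1 to compound 4 (0.06 log units; within the scatter), with hydrogen in place of methyl on an aromatic carbon of the six-membered aromatic ring of carbon only. The earlier compounds shown here gave no size for any change at this position, whereas this pair shows that removing the methyl group there leaves the number within the scatter, so on the core of compound 1 this methyl group has no measurable bearing on the read-out in this assay. Nothing measured here bears on why this step is so small.

The compounds shown leave open whether a different group on this aromatic carbon, such as an amine, a carboxylic acid or a longer chain, would move the number beyond the scatter, since hydrogen and methyl are the only two compared at this place on this core. They also leave open whether hydrogen in place of methyl would give a step of similar size on the core of compound 2, or whether this result holds only for the core of compound 1.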